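Swapping Fluoro for Chloro on the Urea Aryl Ring

The source may report more compounds than this note shows. Statements on the series, on what has been measured and on what is new or still open speak of the compounds shown alone.

Compound 3 `CN(C)CCCn1cnnc1-c1cc(Oc2ccc(NC(=O)Nc3ccc(F)c(F)c3)cc2F)ccn1` gives 1080 nM in a functional assay on NCI-H460 cells (Homo sapiens) for antiproliferative activity, read by MTT assay, with a stated time of 72 h (on this read-out higher numbers stand for weaker inhibition and lower numbers for stronger inhibition), the lowest of the three numbers, though compound 1 `CN(C)CCn1cnnc1-c1cc(Oc2ccc(NC(=O)Nc3ccc(F)c(Cl)c3)cc2F)ccn1` with 1580 nM and compound 2 `CN(C)CCCn1cnnc1-c1cc(Oc2ccc(NC(=O)Nc3cccc(C(F)(F)F)c3)cc2F)ccn1` with 1790 nM both lie within the scatter of it. Going by the values given here, the only single-point step measured so far, a 1.7-fold lower number from compound 2 to compound 3 (0.22 log units; within the scatter), was itself within the scatter. Compound 4 `CN(C)CCCn1cnnc1-c1cc(Oc2ccc(NC(=O)Nc3ccc(F)c(Cl)c3)cc2F)ccn1` differs from compound 3 by chloro in place of fluoro on an aromatic carbon. Among the compounds with values here, no measured step bears directly on this change; compound 1 carries the same 3-chloro-4-fluorophenyl group on a shorter chain, and its number lies close to that of compound 3. A step of a 1.1-fold higher number from compound 3 to compound 4 (0.05 log units; within the scatter) is therefore expected, no larger than the scatter. Compound 4 is estimated at 1200 nM, with a range from 600 nM to 2400 nM.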

Compound 4, half-maximal inhibitory concentration: 1270 nM
Beside the measured number, compound 4's estimate is 1.1-fold (0.02 log units) below it; low and high end bracket the measured number.
By their numbers in this assay, from the lowest: compounds 3, 4, 1 and 2 (each within the scatter of the next).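

In this assay, chloro in place of fluoro on this aromatic carbon stays within the scatter (a 1.2-fold higher number from compound 3 to compound 4 (0.07 log units; within the scatter)). So do the 3-chloro-4-fluorophenyl group in place of 3-(trifluoromethyl)phenyl (a 1.4-fold lower number from compound 2 to compound 4 (0.15 log units; within the scatter)) and (dimethylamino)methyl in place of dimethylamino on the chain (a 1.2-fold lower number from compound 1 to compound 4 (0.09 log units; within the scatter)), so none of these three single-place differences separates the compounds. No supporting measurement bears on this result. Still open, going by these compounds, is whether a bromo or methoxy group on this carbon, or a morpholine in place of the dimethylamino group, would give a step beyond the scatter.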